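Cyano to isopropyl in a nearly inactive series

The source may report more compounds than this note shows. Statements on the series, on what has been measured and on what is new or still open speak of the compounds shown alone.

In an ADME assay on L6 cells (Rattus norvegicus) for cytotoxicity, read by resazurin assay, with a stated time of 72 h (on this read-out lower numbers stand for stronger inhibition and higher numbers for weaker inhibition), compound 1 (`OC(c1ccc(Cl)cc1)(c1ccncn1)c1ccccc1Cl`) gives > 100000 nM, which is a limit of the assay. Compound 2 (`N#Cc1ccc(C(O)(c2ccc(Cl)cc2)c2cccnc2)cc1`) gives > 100000 nM, also a limit. Within the data shown here, compound 3 (`N#Cc1ccc(C(O)(c2ccc(C(F)(F)F)cc2)c2cccnc2)cc1`) gives 76500 nM, the only actual number so far. The reference point is the limit of > 100000 nM in this assay, at which 2 of the 3 values shown sit.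

Compound 4 (`CC(C)c1ccc(C(O)(c2ccc(C(F)(F)F)cc2)c2cccnc2)cc1`) has isopropyl in place of cyano on an aromatic carbon, para to a large group: isopropyl in place of cyano on an aromatic carbon. Among the measured compounds shown here, the only measured step, an at least 1.3-fold lower number from compound 2 to compound 3 (0.11 log units; that floor lies within the scatter), is a change of trifluoromethyl in place of chloro, not at this place. No step beyond the scatter is therefore expected in this assay. The expected step is a 1.5-fold lower number from compound 3 to compound 4 (0.18 log units; within the scatter). For compound 4 the estimate is 50000 nM, with an expected range of 15000 nM to 100000 nM.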

Compound 4, half-maximal inhibitory concentration: 56300 nM
For compound 4 the middle estimate is 1.1-fold (0.05 log units) below the measured one; measured number inside the range.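

In this assay isopropyl in place of cyano gives a 1.4-fold lower number from compound 3 to compound 4 (0.13 log units; within the scatter) and so moves the read-out no further than the scatter at this position. Unlike the earlier step, which rests on a limit, this one joins two actual numbers, so its size can be read directly. Actual numbers remain few in the series: the limit of > 100000 nM in this assay, at which 2 of the 4 values shown sit.

As far as these compounds go, whether an amine or a carboxylic acid at this position would give a step beyond the scatter stays open. The same holds for a longer chain in place of isopropyl.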